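The source may report more compounds than this note shows. Statements on the series, on what has been measured and on what is new or still open speak of the compounds shown alone.

Measured so far in an ADME assay on HepG2 cells (Homo sapiens) for cytotoxicity, with a stated time of 72 h; on this read-out lower numbers stand for an effect already at smaller amounts and higher numbers for an effect only at larger amounts of compound:
Compound 1 `Cc1cc(NC(=O)Nc2ccccc2OC(F)(F)F)c2ccccc2n1`: > 25000 nM
Compound 2 `Cc1cc(NC(=O)Nc2ccccc2C(F)(F)F)c2ccccc2n1`: > 25000 nM
Compound 3 `Cc1cc(NC(=O)Nc2ccccc2F)c2ccccc2n1`: > 25000 nM

Each of these entries is a limit of the assay and not a number. In this assay compound 3 gives > 25000 nM, which is such a limit. It shares this position with the other two compounds, as the series shows: the limit of > 25000 nM in this assay, at which 3 of the 3 values shown sit.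

The next compound, compound 4 `Cc1cc(NC(=O)Nc2ccccc2[N+](=O)[O-])c2ccccc2n1`, keeps the shared core and changes one group, with nitro in place of fluoro on an aromatic carbon, ortho to a large group: nitro in place of fluoro on an aromatic carbon.

Three measured exchanges of one group for another bear on this change. They are a step that the two limits leave unreadable from compound 1 to compound 2, a step that the two limits leave unreadable from compound 1 to compound 3 and a step that the two limits leave unreadable from compound 2 to compound 3. None of them has a readable size, so the series offers no measured effect of such an exchange to carry over to nitro. The expectation is therefore no step beyond the scatter, and compound 4 is expected to stay at or close to the same limit.

The expected change is a step that the limit leaves unreadable from compound 3 to compound 4.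

For compound 4 the estimated value is 28000 nM, with an expected range from 10000 nM to 50000 nM.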

Compound 4, half-maximal effective concentration: > 25000 nM
Compound 4 gave a limit, no number; the forecaster's own chance of this, stated with the estimate: 75%; the middle value does not contradict the limit.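

In this assay compound 4 gives > 25000 nM, which is a limit and not a number, so its steps to compound 1, compound 2 and compound 3 cannot be read. The compounds shown leave open whether exchanging these groups changes the read-out at all, as all of them stand at one position: the limit of > 25000 nM in this assay, at which 4 of the 4 values shown sit.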